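The source may report more compounds than this note shows. Statements on the series, on what has been measured and on what is new or still open speak of the compounds shown alone.

Compound 1 `CCCCc1nc(=O)c(S(=O)(=O)c2ccc(-n3ccccc3=O)cc2)c(O)n1-c1c(OC)cccc1OC` and compound 2 `CCCCc1nc(=O)c(S(=O)(=O)c2ccc(-n3cc(Cl)ccc3=O)cc2)c(O)n1-c1c(OC)cccc1OC` share a core, and in an ADME assay on microsomes from liver (Homo sapiens) for metabolic stability, using NADPH, with a stated time of 10 min (a lower number here means that less of the compound is left, a higher number that more of the compound is left), compound 1 gives 87%, while compound 2 gives 94%. The change between them is chloro in place of hydrogen on an aromatic carbon, and it gave a number 7 percentage points higher from compound 1 to compound 2 (within the scatter). Compound 3 `CCCCc1[nH]c(=O)c(S(=O)(=O)c2ccc(-n3ccccc3=O)cc2)c(O)c1-c1c(OC)cccc1OC` has a different core; how the two cores differ is not broken down here. In this assay compound 3 gives 100%, which sits within the scatter of compound 2 but beyond it from compound 1. Compound 4 `CCCCc1[nH]c(=O)c(S(=O)(=O)c2ccc(-n3cc(Cl)ccc3=O)cc2)c(O)c1-c1c(OC)cccc1OC` carries the same change relative to compound 3, namely (chloro in place of hydrogen on an aromatic carbon). Because the earlier step of a number 7 percentage points higher from compound 1 to compound 2 (within the scatter) stayed within the scatter, the step from compound 3 to compound 4 is expected to be a number 2 percentage points lower from compound 3 to compound 4 (within the scatter). Compound 4 is therefore expected to give about 98%, between 90% and 100%.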

Compound 4, percent of the compound remaining: 97%
For compound 4 the middle estimate is 1 percentage points above the measured one; the range from low to high includes it.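

In this assay, chloro in place of hydrogen on an aromatic carbon gave a number 3 percentage points lower from compound 3 to compound 4 (within the scatter), and this can be set beside the same change on the other core: the same change on two cores in this assay, a number 7 percentage points higher (within the scatter) from compound 1 to compound 2 and a number 3 percentage points lower (within the scatter) from compound 3 to compound 4, 10 percentage points apart, within the scatter of two such steps. The two steps therefore give no sign that this change behaves differently on the two cores, and neither step stands out from the usual scatter. This does not show that the change has no effect at all or that it would behave the same way on a third core, as only two cores are shown and a small effect could stay hidden in the scatter.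

The compounds shown leave open what other groups would do at this place, two atoms from the ring nitrogen, such as a methyl, a methoxy or a nitrile. They also leave open whether an amine or a carboxylic acid there would keep the read-out in the same range.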